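The source may hold more compounds than are shown below. What is called first, only, known or untested is meant among the compounds shown, and "the series" means these compounds.

Compound 1 `C[C@@H](O)[C@H](NC(=O)CN(c1nc(Cl)nc2[nH]cnc12)C1CC1)C(=O)O` gives 24% in a functional assay on the whole organism (Tail, strain ICR) with Mus musculus as the target, in the tail flick test, with a stated time of 150 min, at a dose of 25 umol/kg by the oral route; on this read-out higher numbers stand for a stronger effect at the one dose given and lower numbers for a weaker effect.
Compound 2 `CSCC[C@H](NC(=O)CN(c1nc(Cl)nc2[nH]cnc12)C1CC1)C(=O)O` gives 4.14% in this assay.

Among the compounds with values here, compound 2 stands lowest of the two numbers; the only step, a number 19.9 percentage points lower from compound 1 to compound 2 (beyond the scatter), is of modest size. Compound 3 `CC(C)C[C@H](NC(=O)CN(c1nc(Cl)nc2[nH]cnc12)C1CC1)C(=O)O` differs from compound 2 by isopropyl in place of (methylsulfanyl)methyl on a saturated chain carbon, two bonds along the chain from an amide-type nitrogen and a carbonyl carbon. Within the data shown here, no measured step removes the sulfur from this side chain, so that one step bears on the change only in showing that this position moves the read-out in this assay by a modest amount. Compound 3 is therefore expected to show a small rise, a number 7.9 percentage points higher from compound 2 to compound 3 (within the scatter), within wide bounds. Compound 3 is estimated at 12%, between 0% and 35%.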

Compound 3, a percentage reported as activity, at one dose (the size of the read-out at that dose, not a potency): 9.13%
Compound 3: the middle estimate sits 2.9 percentage points above what was measured; measured number inside the range.
By their numbers in this assay, from the lowest: compounds 2 and 3 (each within the scatter of the next); then compound 1.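

In this assay, the step of a number 5 percentage points higher from compound 2 to compound 3 (within the scatter) shows that isopropyl can take the place of (methylsulfanyl)methyl at this position with no difference beyond the scatter, so the sulfur is not needed for a number of this size. The step of a number 14.9 percentage points lower from compound 1 to compound 3 (beyond the scatter) shows that 1-hydroxyethyl, not only in comparison with 2-(methylsulfanyl)ethyl but also with isobutyl, gives the highest number of the three. No measurement is available to explain these differences. From the compounds shown here alone, it remains open how a carboxylic acid or an amine on this side chain would read in this test, and whether a phenyl ring here would reach the number of compound 1.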